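Furan-2-yl ester compared with the cyclopropyl ester

The compounds below may be only part of what the source reports. "The series", "measured", "known", "first", "only" and "open" are said of these compounds alone.

In an ADME assay on L02 cells (Homo sapiens) for cytotoxicity, read by MTT assay (a higher number here means a weaker inhibitor, a lower number a stronger inhibitor), compound 1 `COc1ccc(/C=C/C(=O)c2ccc(OC)c3c2OC(C)(C)C=C3)cc1OCCCN(C)C` gives 8600 nM. Compound 2 `COc1ccc(/C=C/C(=O)c2ccc(OC)c3c2OC(C)(C)C=C3)cc1OC(=O)C1CC1` gives > 10000 nM, which is a limit and not a number. Compound 3 `COc1ccc(/C=C/C(=O)c2ccc(OC)c3c2OC(C)(C)C=C3)cc1OC(=O)c1ccco1` differs from it by furan-2-yl in place of cyclopropyl on a carbonyl carbon, with furan-2-yl in place of cyclopropyl on a carbonyl carbon. Going by the values given here, the one measured step, an at least 1.1-fold higher number from compound 1 to compound 2 (0.06 log units; that floor lies within the scatter), has a floor within the scatter and concerns a different replacement, so it gives only weak guidance. No step beyond the scatter is expected in this assay, and the expected size is a step that the limit leaves unreadable from compound 2 to compound 3. For compound 3 the estimate is 12000 nM, with an expected range of 6000 nM to 25000 nM.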

Compound 3, half-maximal inhibitory concentration: > 10000 nM
Compound 3: a limit, no number; the forecaster's own chance of this, stated with the estimate: 70%; the middle value does not contradict the limit.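

In this assay, the furan-2-yl ester ends at the same limit as the cyclopropyl ester, so a five-membered aromatic ring on the carbonyl carbon gives a readable number no more than the three-membered ring did. The comparison with the 3-(dimethylamino)propyl group yields only a floor: an at least 1.1-fold higher number from compound 1 to compound 3 (0.06 log units; that floor lies within the scatter). The step between the two esters cannot be read because both stop at the limit: the limit of > 10000 nM in this assay, at which 2 of the 3 values shown sit.

On these data alone, the true values of both esters remain open. Also open, as far as these compounds go, is whether a carboxylic acid or a longer amine chain on this oxygen would give a number in this assay.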